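A few compounds are considered here, and "the series" means these few. Any claim that something is new, unique, unknown or untested is made for them only; others in the source may bear on it.

Compound 3, `CC(C)(C)c1ccc(C(=O)N2CCC3(CC2)C(=O)N(CC(=O)NCCCCCNS(C)(=O)=O)CN3c2ccccc2)cc1`, sits in the middle of three measured compounds in an assay on HEK293 cells for displacement of a labelled ligand from NPC1-like intracellular cholesterol transporter 1 (Homo sapiens); a lower number here means a stronger inhibitor, a higher number a weaker inhibitor: compound 3 gives 5500 nM. Its nearest neighbour is compound 2, `CC(C)(C)OC(=O)NCCCNC(=O)CN1CN(c2ccccc2)C2(CCN(C(=O)c3ccc(C(C)(C)C)cc3)CC2)C1=O`, for which compound 2 gives 4500 nM in this assay; the gap a 1.2-fold higher number from compound 2 to compound 3 (0.09 log units; within the scatter) lies within the scatter. The weakest of the three is compound 1, `CC(C)(C)c1ccc(C(=O)N2CCC3(CC2)C(=O)N(CC(=O)NCCC(=O)O)CN3c2ccccc2)cc1`, and compound 1 gives 11400 nM in this assay. The two steps that leave compound 1, a 2.5-fold lower number from compound 1 to compound 2 (0.40 log units; beyond the scatter) and a 2.1-fold lower number from compound 1 to compound 3 (0.32 log units; beyond the scatter), show that exchanging the carboxy group for a longer chain bearing a protected amine or a methanesulfonamide helps modestly.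

Compound 4, `CC(C)(C)c1ccc(C(=O)N2CCC3(CC2)C(=O)N(CC(=O)NCNS(C)(=O)=O)CN3c2ccccc2)cc1`, is not yet measured. It differs from compound 3 by methanesulfonamido in place of 4-(methanesulfonamido)butyl on a saturated chain carbon bound to an amide-type nitrogen. Among the compounds with values here, none of the measured steps varies chain length alone; the step of a 1.2-fold higher number from compound 2 to compound 3 (0.09 log units; within the scatter) only shows that the two chain ends are interchangeable within the scatter. Since the benefit seen in a 2.1-fold lower number from compound 1 to compound 3 (0.32 log units; beyond the scatter) came with the longer chain, compound 4 is expected to be somewhat weaker, by about a 1.4-fold higher number from compound 3 to compound 4 (0.13 log units; within the scatter) in this assay. Compound 4 is therefore estimated at 7500 nM, within a range of 3500 nM to 16000 nM.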

Compound 4, half-maximal inhibitory concentration: 3200 nM
Compound 4: the middle estimate sits 2.3-fold (0.37 log units) above what was measured; measured number below the stated range.
By their numbers in this assay, from the lowest: compounds 4, 2 and 3 (each within the scatter of the next); then compound 1.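

Cutting the chain back to the methanesulfonamido group on a saturated chain carbon bound to an amide-type nitrogen changes nothing that can be told in this assay: the step is a 1.7-fold lower number from compound 3 to compound 4 (0.24 log units; within the scatter), and the comparison with the protected amine, a 1.4-fold lower number from compound 2 to compound 4 (0.15 log units; within the scatter), also stays within the scatter. The benefit over the carboxy compound therefore does not depend on the longer chain, as a 3.6-fold lower number from compound 1 to compound 4 (0.55 log units; beyond the scatter) stands beyond the scatter with the short methanesulfonamido group in place of carboxymethyl. Nothing given here explains why the short and long chains read alike.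

The compounds shown leave open whether a free amine or an acetamide on the same short chain would match the methanesulfonamide. They also leave open how a carboxylic acid would read on a longer chain, so the effects of the end group and of chain length remain unseparated for the acid.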